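Urea series: methoxy entering beside chloro, permeability expectation

The source may hold more compounds than are shown below. What is called first, only, known or untested is meant among the compounds shown, and "the series" means these compounds.

The series shares the core of compound 1 `Cc1cc(NC(=O)Nc2ccc(C)c(Cl)c2)c2ccccc2n1`, which in an ADME assay for permeability, using PAMPA, at pH 7.4 (a lower number here means that the compound crosses the layer more slowly, a higher number that the compound crosses the layer faster), gives 262 10^-6 cm/s. Compound 2 `COc1ccc(NC(=O)Nc2cc(C)nc3ccccc23)cc1` gives 787 10^-6 cm/s in this assay, and compound 3 `Cc1cc(NC(=O)Nc2cccc(Cl)c2)c2ccccc2n1` gives 566 10^-6 cm/s. Among the three numbers compound 3 stands second highest: its nearest neighbour is compound 2, within the scatter, and its furthest is compound 1, beyond the scatter. Among the measured compounds shown here, the only step measured in one place is a 2.2-fold higher number from compound 1 to compound 3 (0.33 log units; beyond the scatter).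

Compound 4 `COc1ccc(NC(=O)Nc2cc(C)nc3ccccc23)cc1Cl` differs from compound 3 by methoxy in place of hydrogen on an aromatic carbon, the new group sitting ortho to a chloro group and para to a large group. For the measured compounds named here, no measured step covers a methoxy entering; the step from compound 1 to compound 3 concerns a methyl and does not bear on it directly. Compound 2, which carries a methoxy on that ring, gives 787 10^-6 cm/s, within the scatter of compound 3, so no change beyond the scatter is expected for compound 4, and a 1.1-fold higher number from compound 3 to compound 4 (0.03 log units; within the scatter) is the estimated step. Compound 4 is expected at 600 10^-6 cm/s, with a range from 300 10^-6 cm/s to 1000 10^-6 cm/s.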

Compound 4, apparent permeability: 336 10^-6 cm/s
Compound 4: middle estimate off by 1.8-fold (0.25 log units), on the high side, and the stated range covers the measured number.
By their numbers in this assay, from the lowest: compounds 1, 4, 3 and 2 (each within the scatter of the next, the first and the last beyond it).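

In this assay, methoxy in place of hydrogen on this aromatic carbon, ortho to a chloro group and para to a large group, now has a direct reading, which gives a 1.7-fold lower number from compound 3 to compound 4 (0.23 log units; within the scatter) and so stays inside the scatter. Among the compounds shown here, with the methoxy held in place, chloro in place of hydrogen gives a 2.3-fold lower number from compound 2 to compound 4 (0.37 log units; beyond the scatter) and is the only new step to leave the scatter. Methoxy in place of methyl gives a 1.3-fold higher number from compound 1 to compound 4 (0.11 log units; within the scatter) and does not separate the two groups on this ring. Nothing at hand explains any of these steps. Still open, from the compounds shown here alone, is whether an amine or a carboxylic acid at this position would give a step beyond the scatter, and whether fluoro in place of the chloro group would repeat the chloro step.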